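This account rests on a few compounds, and the source may have more. Where it says the series, first, only, none or still open, it means among the compounds named here.

Measured so far in a functional assay on HeLa cells (Homo sapiens) for antiproliferative activity, read by MTT assay, with a stated time of 48 h; a higher number here means a weaker inhibitor, a lower number a stronger inhibitor:

Compound 1 `O=C(CSc1nnc(NC(=O)CCl)s1)Nc1ccc(Cl)cn1`: 3600 nM
Compound 2 `O=C(CSc1nnc(NC(=O)CCl)s1)Nc1ccc(Br)cn1`: 3400 nM
Compound 3 `O=C(CCl)Nc1ccc(SCC(=O)Nc2ccc(Cl)cn2)cc1`: 2500 nM

Compound 1 and compound 2 share one core and differ by bromo in place of chloro on an aromatic carbon. That change gave a 1.1-fold lower number from compound 1 to compound 2 (0.02 log units; within the scatter). Compound 3 is built on another core; the difference between the two cores is not broken down here. Compound 4 `O=C(CCl)Nc1ccc(SCC(=O)Nc2ccc(Br)cn2)cc1` has not been measured; it differs from compound 3 by bromo in place of chloro on an aromatic carbon. The surroundings of the exchanged group read the same in both pairs, so this is the same change made on a second core. Because a 1.1-fold lower number from compound 1 to compound 2 (0.02 log units; within the scatter) stayed within the scatter, the expected step from compound 3 to compound 4 is a 1.1-fold lower number from compound 3 to compound 4 (0.04 log units; within the scatter). Compound 4 is therefore estimated at 2300 nM, with a likely span from 1200 nM to 4500 nM.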

Compound 4, half-maximal inhibitory concentration: 2100 nM
Compound 4: middle estimate off by 1.1-fold (0.04 log units), on the high side; measured number inside the range.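

In this assay, putting 5-bromopyridin-2-yl in place of 5-chloropyridin-2-yl gave a 1.2-fold lower number from compound 3 to compound 4 (0.08 log units; within the scatter), so on this second core, as on the first, the exchange made no difference that can be told from scatter. The two cores agree on this exchange: the same change on two cores in this assay, a 1.1-fold lower number (0.02 log units; within the scatter) from compound 1 to compound 2 and a 1.2-fold lower number (0.08 log units; within the scatter) from compound 3 to compound 4, 1.1-fold (0.05 log units) apart, within the scatter of two such steps. This shows that a step too small to read on one core stayed too small to read on the other, but it does not show that a larger step would carry over, as neither step here lies beyond the scatter.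

All four compounds carry chloro or bromo at this place on the ring. Going by these compounds, what a methyl, a methoxy or a nitrile there would do on either core remains open.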